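Chloro-to-hydrogen step on a fused core: notes

The source may report more compounds than this note shows. Statements on the series, on what has been measured and on what is new or still open speak of the compounds shown alone.

Measured so far:
compound 1 `ClCc1ccc(Cn2cnc3nc(Cl)nc(Cl)c32)cc1`, 5010 nM
compound 2 `ClCc1ccccc1Cn1cnc2ncnc(Cl)c21`, 26900 nM
compound 3 `ClCc1ccccc1Cn1cnc2nc(Cl)nc(Cl)c21`, 20900 nM

All values come from a functional assay on SK-OV-3 cells (Homo sapiens) for cytotoxicity, read by sulforhodamine B assay, with a stated time of 48 h; a lower number here means a stronger inhibitor of growth, a higher number a weaker inhibitor of growth. Compound 1 gives 5010 nM and stands lowest of the three. Compound 3 gives 20900 nM, and compound 2 gives 26900 nM; both sit well beyond the scatter from compound 1. Compound 1 and compound 3 have the same atoms joined differently; the difference between the two cores is not broken down here.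

Compound 3 and compound 2 differ by one change, (hydrogen in place of chloro on an aromatic carbon). Its step is a 1.3-fold higher number from compound 3 to compound 2 (0.11 log units; within the scatter), so the measured values of these two compounds cannot be told apart in this assay.

Compound 4 `ClCc1ccc(Cn2cnc3ncnc(Cl)c32)cc1` is not yet measured. It relates to compound 1 by the same change, (hydrogen in place of chloro on an aromatic carbon), with the place described in identical words. Within the data shown here, the only guide is the single earlier instance, which gave a 1.3-fold higher number from compound 3 to compound 2 (0.11 log units; within the scatter); no second example is available, so the expectation rests on one pair.

Compound 4 is therefore expected to sit close to compound 1, with an estimated step of a 1.3-fold higher number from compound 1 to compound 4 (0.11 log units; within the scatter), because the same change gave a 1.3-fold higher number from compound 3 to compound 2 (0.11 log units; within the scatter). The estimate for compound 4 in this assay is 6500 nM, with a range from 2500 nM to 17000 nM.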

Compound 4, concentration for total growth inhibition: 23400 nM
For compound 4 the middle estimate is 3.6-fold (0.56 log units) below the measured one; the whole stated range lies below it.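

In this assay, putting hydrogen in place of chloro on the aromatic carbon between two ring nitrogen atoms gives a 4.7-fold higher number from compound 1 to compound 4 (0.67 log units; beyond the scatter), a modest loss of growth inhibition that is clearly readable in this pair. The size of this step does not carry over unchanged between the two cores in this series: the same change on two cores in this assay, a 1.3-fold higher number (0.11 log units; within the scatter) from compound 3 to compound 2 and a 4.7-fold higher number (0.67 log units; beyond the scatter) from compound 1 to compound 4, 3.6-fold (0.56 log units) apart, beyond the scatter of two such steps. The two pairs show that the core can alter the size of the step, but they do not explain the gap, give a rule for the change, or show how it would behave on any further core.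

The compounds shown leave open whether a different group on this aromatic carbon, such as fluoro, methoxy or an amine, would give a step of similar size on each core. They also leave open how much of the difference between the cores depends on the chloromethyl group, which could be tested by replacing it with a plain methyl or a hydroxymethyl group on both cores and repeating the chloro-to-hydrogen comparison.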